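Methyl in place of hydrogen: compound 3 to compound 4

The source may report more compounds than this note shows. Statements on the series, on what has been measured and on what is new or still open speak of the compounds shown alone.

Values so far in a functional assay on the whole organism for antagonist activity, with Mus musculus as the target; on this read-out higher numbers stand for an effect only at larger amounts of compound and lower numbers for an effect already at smaller amounts
compound 1 `CC(=O)N(C)C(C)C#CCn1ccnc1` gives > 100 mg/kg as a limit, not a number
compound 2 `CC(=O)N(C)C(C)C#CCn1cncc1C` gives 80 mg/kg as a number
compound 3 `CC(C#CCn1ccnc1)N1CCCC1=O` gives 45 mg/kg as a number

Within the data shown here, compound 3 lies within the usual scatter of compound 2, the only other compound with a true number. The limit of compound 1 gives no position against either.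

Compound 4 `Cc1cncn1CC#CC(C)N1CCCC1=O` follows from compound 3 by methyl in place of hydrogen on an aromatic carbon with no other change to the structure.

The same exchange occurs once among the measured pairs, as an at least 1.2-fold lower number from compound 1 to compound 2 (0.09 log units; that floor lies within the scatter) and that step starts from the limit of > 100 mg/kg in this assay, at which 1 of the 3 values shown sits, so it fixes only a floor. On the strength of that single step from compound 1 to compound 2, no shift beyond the scatter is expected in this assay and a slight move to a lower number is the most it suggests. The estimated step is a 1.3-fold lower number from compound 3 to compound 4 (0.11 log units; within the scatter) as an expectation only. For compound 4 the expected value is 35 mg/kg with an estimated range from 15 mg/kg to 80 mg/kg for a single measurement.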

Compound 4, dose for half-maximal effect: 25.4 mg/kg
Compound 4: middle estimate off by 1.4-fold (0.14 log units), on the high side; measured number inside the range.
By their numbers in this assay, from the lowest: compounds 4, 3 and 2 (each within the scatter of the next, the first and the last beyond it). At a limit, above all of these: compound 1.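

In this assay, methyl in place of hydrogen on an aromatic carbon now has a true number at both ends of a step, a 1.8-fold lower number from compound 3 to compound 4 (0.25 log units; within the scatter), whereas the earlier step gave only a floor. This position, on the five-membered aromatic ring with 2 nitrogen, therefore carries methyl on the core of compound 3 with no shift beyond the scatter. Both cores now show the change, but no difference between them can be fixed: the same change on two cores in this assay, an at least 1.2-fold lower number (0.09 log units; that floor lies within the scatter) from compound 1 to compound 2 and a 1.8-fold lower number (0.25 log units; within the scatter) from compound 3 to compound 4; the limit leaves it open whether they differ

Left open is whether a larger group at this position, such as ethyl, an aminomethyl group or a carboxylic acid, would move the number beyond the scatter. Compound 1, at > 100 mg/kg, remains a limit and not a number.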